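The source may report more compounds than this note shows. Statements on the series, on what has been measured and on what is new or still open speak of the compounds shown alone.

Of the compounds shown here, three sharing one core have been tested in an ADME assay on MT4 cells (Homo sapiens) for cytotoxicity, read by MTT assay, with a stated time of 5 days; a higher number here means that more compound is tolerated, a lower number that less compound is tolerated. Here compound 1 `COc1cc2nc([S+]([O-])CC(=O)Nc3cccc(Cl)c3)nc(Nc3c(Cl)cc(/C=C/C#N)cc3Cl)c2cc1OC` gives 68900 nM, and compound 3 `COc1cc2nc([S+]([O-])CC(=O)Nc3ccc(C)cc3)nc(Nc3c(Cl)cc(/C=C/C#N)cc3Cl)c2cc1OC` gives 32200 nM. Compound 2 `COc1cc2nc([S+]([O-])CC(=O)Nc3ccc(C#N)cc3)nc(Nc3c(Cl)cc(/C=C/C#N)cc3Cl)c2cc1OC` reads >= 188000 nM, which is a limit of the assay and not a number. Compound 3 therefore stands lowest of the three, the one tolerated at the smallest concentration.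

The next compound is compound 4 `COc1cc2nc([S+]([O-])CC(=O)Nc3c(C)cc(C)cc3C)nc(Nc3c(Cl)cc(/C=C/C#N)cc3Cl)c2cc1OC`, with 2,4,6-trimethylphenyl in place of 4-methylphenyl on an amide-type nitrogen. The measured steps bearing on this change all swap the group at that same nitrogen. They are a 2.1-fold lower number from compound 1 to compound 3 (0.33 log units; beyond the scatter), which is modest, together with an at least 2.7-fold higher number from compound 1 to compound 2 (0.43 log units; beyond the scatter) and an at least 5.8-fold lower number from compound 2 to compound 3 (0.76 log units; beyond the scatter), which both involve the cyano compound. None of them adds methyl groups to a ring that already carries one, so they give no firm direction. The two compounds without a nitrile on this group, compound 1 and compound 3, differ only modestly, so a small change is expected. An estimated 1.2-fold higher number from compound 3 to compound 4 (0.07 log units; within the scatter) is expected, within the scatter. For compound 4 the expected value is 38000 nM, with an estimated range from 14000 nM to 110000 nM.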

Compound 4, half-maximal cytotoxic concentration: 8870 nM
Estimate against measurement, compound 4: 4.3-fold (0.63 log units) above, outside the stated range (below it).
By their numbers in this assay, from the lowest: compound 4; then compound 3; then compound 1. At a limit, above all of these: compound 2.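

In this assay, 2,4,6-trimethylphenyl in place of 4-methylphenyl on the amide-type nitrogen gives a 3.6-fold lower number from compound 3 to compound 4 (0.56 log units; beyond the scatter), which shows that adding more methyl to a ring that already carries one does change tolerance at this position. Against the chlorinated ring, the change gives a 7.8-fold lower number from compound 1 to compound 4 (0.89 log units; beyond the scatter), and compound 4 is now the compound tolerated at the smallest concentration of the four. Compound 2 holds a limit of the assay and not a number, so an at least 21-fold lower number from compound 2 to compound 4 (1.32 log units; beyond the scatter) gives only the smallest possible size of that gap: the limit of >= 188000 nM in this assay, at which 1 of the 4 values shown sits.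

The compounds shown cannot separate what each methyl group of compound 4 contributes. On these data alone, how a phenyl ring carrying an amine or a carboxylic acid would behave on this nitrogen also stays open.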